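A few compounds are considered here, and "the series" means these few. Any claim that something is new, unique, unknown or untested is made for them only; others in the source may bear on it.

Measured so far:
compound 1 `O=C(O)CCCCC1=CC[C@@H]2[C@@H](/C=C/[C@@H](O)COc3ccccc3)[C@H](O)C[C@@H]2OC1` — > 10000 nM
compound 2 `O=C(O)CCCCCC1=CC[C@@H]2[C@@H](/C=C/[C@@H](O)COc3ccccc3)[C@H](O)C[C@@H]2OC1` — > 10000 nM
compound 3 `O=C(O)CCC[C@@H]1CC[C@@H]2[C@@H](/C=C/[C@@H](O)COc3ccccc3)[C@H](O)C[C@@H]2OC1` — > 10000 nM

In an ADME assay on CHO cells for agonist activity at prostacyclin receptor (Homo sapiens), read by HTRF and cAMP accumulation (a higher number here means that more compound is needed for the effect, a lower number that less compound is needed), compound 1 reaches only the limit of the assay, > 10000 nM. Compound 2 also stops at a limit in this assay, > 10000 nM. Compound 3 too gives only a limit, > 10000 nM. The change from compound 1 to compound 2 is carboxymethyl in place of carboxy on a saturated chain carbon, four bonds along the chain from a double-bonded ring carbon; its step, a step that the two limits leave unreadable from compound 1 to compound 2, cannot be read because both ends sit at the limit of > 10000 nM in this assay, at which 3 of the 3 values shown sit. The difference between the core of compound 1 and the core of compound 3 is not broken down here.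

Compound 4 `O=C(O)CCCC[C@@H]1CC[C@@H]2[C@@H](/C=C/[C@@H](O)COc3ccccc3)[C@H](O)C[C@@H]2OC1` has not been measured. It differs from compound 3 by carboxymethyl in place of carboxy on a saturated chain carbon, three bonds along the chain from a saturated ring carbon, the same kind of change as before, though here the place is three bonds along the chain from a saturated ring carbon rather than four bonds from a double-bonded ring carbon. The step from compound 3 to compound 4 is expected to be a step that the limit leaves unreadable from compound 3 to compound 4, resting on the unreadable a step that the two limits leave unreadable from compound 1 to compound 2 and on compound 3 sitting at a limit. Compound 4 is estimated at 15000 nM, with a range from 3000 nM to 60000 nM.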

Compound 4, half-maximal effective concentration: > 10000 nM
Compound 4: only a limit was reported; the forecaster's own chance of this, stated with the estimate: 85%; the middle value lies beyond the limit too.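

Compound 3 and compound 4 both stop at a limit, so no step between them can be read: the limit of > 10000 nM in this assay, at which 4 of the 4 values shown sit.

The compounds shown leave open how far each lies beyond that limit, and whether carboxymethyl in place of carboxy changes anything.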